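The compounds below may be only part of what the source reports. "The series", "measured", "known", "first", "only" and "open" are said of these compounds alone.

Of the compounds shown here, three share one core and have been tested so far. Compound 1 `C[C@@H]1CCN(c2cc(-c3ccccc3)nc3ncnn23)C[C@@H]1N(C)c1ncnc2[nH]ccc12` carries a phenyl on its aromatic carbon, compound 2 `CCc1cc(N2CC[C@@H](C)[C@@H](N(C)c3ncnc4[nH]ccc34)C2)n2ncnc2n1` an ethyl in the same position, and compound 3 `Cc1cc(N2CC[C@@H](C)[C@@H](N(C)c3ncnc4[nH]ccc34)C2)n2nc(SCC3CC3)nc2n1` a methyl together with a (cyclopropylmethyl)sulfanyl group. In a functional assay on HGC-27 cells (Homo sapiens) for inhibition, read by MTT assay, with a stated time of 72 h (a higher number here means a weaker inhibitor, a lower number a stronger inhibitor), compound 1 gives only a limit, > 100000 nM. Compound 2 likewise returns a limit in this assay, > 100000 nM. The step from phenyl to ethyl, a step that the two limits leave unreadable from compound 1 to compound 2, therefore cannot be read, because both ends sit at the limit of > 100000 nM in this assay, at which 2 of the 3 values shown sit. Going by the values given here, compound 3 is the only one with a measured number: in this assay compound 3 gives 21400 nM, so it stands as the sole readable point among the three.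

Compound 4 `Cc1cc(N2CC[C@@H](C)[C@@H](N(C)c3ncnc4[nH]ccc34)C2)n2nc(SCc3ccc(Cl)cc3)nc2n1` is compound 3 with one change, (4-chlorophenyl in place of cyclopropyl on a saturated chain carbon bound to a sulfur). Among the compounds with values here, no measured step touches this part of the molecule, and the single readable step elsewhere is itself unreadable, so there is nothing to transfer. The expected shift from this change is a 1.4-fold lower number from compound 3 to compound 4 (0.15 log units; within the scatter), which lies within the usual scatter. Compound 4 is thus estimated at 15000 nM, with a range from 4000 nM to 60000 nM.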

Compound 4, half-maximal inhibitory concentration: 18400 nM
Compound 4: middle estimate off by 1.2-fold (0.09 log units), on the low side, within the range that was stated.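

Replacing cyclopropyl with 4-chlorophenyl on a saturated chain carbon bound to a sulfur gives, in this assay, a 1.2-fold lower number from compound 3 to compound 4 (0.07 log units; within the scatter), so the two compounds cannot be told apart. Going by these compounds alone, this is the first readable step, and it shows that this position accepts two quite different groups with no change beyond the scatter: a three-membered non-aromatic ring of 3 heavy atoms leaves, and a six-membered aromatic ring carrying chlorine, 7 heavy atoms in all, enters. Nothing measured here explains why the two groups read alike.

Still open, on these data alone, is whether a different kind of group at the same place, such as an amine, a carboxylic acid or a longer chain, would shift the number beyond the scatter, since a carbon ring with or without chlorine is all that this position has carried so far. Also open, as far as these compounds go, is what the sulfur contributes, as an oxygen or an amine nitrogen in its place would be needed to show whether the link itself matters.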